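The source may hold more compounds than are shown below. What is called first, only, known or untested is meant among the compounds shown, and "the series" means these compounds.

Compound 1 `COc1ccccc1Nc1nc(SCc2ccc(C(F)(F)F)cc2)nc2ccccc12`: in a functional assay on MGC-803 cells (Homo sapiens) for cytotoxicity, read by MTT assay, with a stated time of 72 h (on this read-out lower numbers stand for stronger inhibition and higher numbers for weaker inhibition), compound 1 gives > 50000 nM, which is a limit of the assay rather than a number.
Compound 2 `COc1ccc(Nc2nc(SCc3ccc(C(F)(F)F)cc3)nc3ccccc23)c(OC)c1`: compound 2 gives > 50000 nM, again only a limit.
Compound 3 `COc1ccc(Nc2nc(SCc3ccc(C(F)(F)F)cc3)nc3ccccc23)cc1OC`: compound 3 gives 16300 nM.

All three share one core and differ only in the methoxy-bearing phenyl ring carried on the nitrogen. Within the data shown here, compound 3 holds the only real number; the other two values sit at the limit of > 50000 nM in this assay, at which 2 of the 3 values shown sit. From compound 1 to compound 2 the change is methoxy in place of hydrogen on an aromatic carbon, and a step that the two limits leave unreadable from compound 1 to compound 2, so nothing about its size can be read. From compound 1 to compound 3 the change is 3,4-dimethoxyphenyl in place of 2-methoxyphenyl on a nitrogen on an aromatic ring, giving an at least 3.0-fold lower number from compound 1 to compound 3 (0.48 log units; beyond the scatter). In the same way there is an at least 3.0-fold lower number from compound 2 to compound 3 (0.48 log units; beyond the scatter).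

The unmeasured compound 4 `COc1cc(Nc2nc(SCc3ccc(C(F)(F)F)cc3)nc3ccccc23)cc(OC)c1OC` differs from compound 3 by methoxy in place of hydrogen on an aromatic carbon. Among the measured compounds shown here, this is the same kind of change as the one from compound 1 to compound 2, not the same one: there the entering methoxy sat meta to a methoxy group and para to a large group, whereas here it sits ortho to a methoxy group, meta to a large group and meta to a methoxy group. Because a step that the two limits leave unreadable from compound 1 to compound 2, the earlier step offers no direction for the new one. For compound 4 the expected step is therefore small, a 1.4-fold lower number from compound 3 to compound 4 (0.13 log units; within the scatter), resting only on compound 3 having 16300 nM as the single fixed point. Compound 4 is expected to give about 12000 nM in this assay, somewhere between 3000 nM and 45000 nM.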

Compound 4, half-maximal inhibitory concentration: 8240 nM
Compound 4: the middle estimate sits 1.5-fold (0.16 log units) above what was measured; measured number inside the range.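

In this assay, methoxy in place of hydrogen on an aromatic carbon gives a 2.0-fold lower number from compound 3 to compound 4 (0.30 log units; within the scatter), so compound 3 and compound 4 cannot be told apart on this read-out. The same kind of change from compound 1 to compound 2 cannot be read, so the two steps cannot be compared, because both of its ends sit at a limit rather than at a number: the limit of > 50000 nM in this assay, at which 2 of the 4 values shown sit. This leaves a single readable case, with the methoxy ortho to a methoxy group, meta to a large group and meta to a methoxy group, and that case shows neither that the change carries over to another setting nor that it fails to.

On these data alone, all four compounds keep the shared core and the trifluoromethyl group and carry only methoxy groups on the ring attached to the nitrogen, so it remains open how a hydroxy group, an amine or a carboxylic acid on that ring would behave in this assay. As far as these compounds go, it is also open whether the same methoxy change would give a readable step on a core with a longer chain in place of the trifluoromethyl-bearing part.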